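A few compounds are considered here, and "the series" means these few. Any claim that something is new, unique, unknown or untested is made for them only; others in the source may bear on it.

Measured compounds:

Compound 1, `OCC(O)Cn1nc2c(Br)c(Br)c(Br)c(Br)c2n1`, gives 98% in a functional assay on MCF7 cells (Homo sapiens) for antiproliferative activity, read by MTT assay, with a stated time of 24 h, tested at 50 uM; a higher number here means a weaker effect of the compound at the concentration tested, a lower number a stronger effect.
Compound 2, `OC(CCn1nc2c(Br)c(Br)c(Br)c(Br)c2n1)c1ccccc1`, gives 28% in this assay.
Compound 3, `OC(CCn1nc2c(Br)c(Br)c(Br)c(Br)c2n1)c1cccc(Br)c1`, gives 14% in this assay.

In this assay compound 1 stands highest of the three numbers, so it shows the weakest effect; compound 2 lies well below it and compound 3 lower still, both gaps beyond the scatter. Among the compounds with values here, the only measured step, a number 14 percentage points lower from compound 2 to compound 3 (beyond the scatter), concerns a bromo in place of hydrogen on an aromatic carbon, a different part of the molecule from the chain on the aromatic nitrogen.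

Compound 4, `C[C@H](O)CCn1nc2c(Br)c(Br)c(Br)c(Br)c2n1`, differs from compound 1 in that chain: 2-hydroxypropyl in place of 1,2-dihydroxyethyl on a saturated chain carbon bound to an aromatic nitrogen. Within the data shown here, no measured step touches this kind of change, since compounds 2 and 3 carry a longer chain that differs from compound 1 in more than one place, so their gap to compound 1 cannot be assigned to the hydroxy groups alone. A small downward shift, or none beyond the scatter, is therefore expected, a number 13 percentage points lower from compound 1 to compound 4 (beyond the scatter). For compound 4 the estimate in this assay is 85%, within a range from 60% to 100%.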

Compound 4, a percentage reported as activity, at one concentration (the size of the read-out at that concentration, not a potency): 105%
Compound 4: the middle estimate sits 20 percentage points below what was measured; measured number outside the range, above it.
By their numbers in this assay, from the lowest: compound 3; then compound 2; then compounds 1 and 4 (each within the scatter of the next).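

Replacing 1,2-dihydroxyethyl with 2-hydroxypropyl on a saturated chain carbon bound to an aromatic nitrogen gives a number 7 percentage points higher from compound 1 to compound 4 (within the scatter) in this assay, so this exchange leaves the read-out unchanged within the usual variation. The entering group has 1 hydrogen-bond donor and 1 acceptor, while the leaving group has 2 of each, and it also adds a defined stereocentre; at this position, neither difference produces a change that can be distinguished from scatter. Nothing available explains why the number holds steady here.

Still open, as far as these compounds go, is whether an amine or a carboxylic acid in place of the hydroxy group of 2-hydroxypropyl, or a longer chain at the same place, would move the number. The compounds shown also leave open whether the opposite configuration at the stereocentre of 2-hydroxypropyl would matter.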